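A few compounds are considered here, and "the series" means these few. Any claim that something is new, unique, unknown or untested is made for them only; others in the source may bear on it.

Compound 2 `CC(C)C(Nc1nccs1)c1ccc(-c2ccc3cccc(F)c3c2)[nH]c1=O` was tested in an ADME assay on microsomes from liver (Rattus norvegicus) for metabolic stability; a higher number here means that the compound lasts longer, a lower number that the compound disappears faster. There compound 2 gives 0.07 h, the lowest of the two numbers obtained, and the nearest measured neighbour is compound 1 `CC(C)C(c1ccc(-c2ccc3cccc(F)c3c2)[nH]c1=O)N1CCCCC1=O`, which in this assay gives 0.102 h. Within the data shown here, the only change between them is a 1.5-fold lower number from compound 1 to compound 2 (0.16 log units; within the scatter). Compound 3 `CCn1ncc2c(F)cc(-c3ccc(C(CC)(CC)c4nnc[nH]4)c(=O)[nH]3)cc21` shows no number in this assay but a limit, > 3 h, as recorded in the limit of > 3 h in this assay, at which 1 of the 3 values shown sits.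

Compound 4 `CC(C)C(Cc1noc(=O)[nH]1)c1ccc(-c2ccc3cccc(F)c3c2)[nH]c1=O` is the next compound to be measured. It differs from compound 2 by a group of 7 heavy atoms (3 carbon, 2 nitrogen, 2 oxygen; one five-membered aromatic ring with 3 hetero atoms) in place of a group of 6 heavy atoms (3 carbon, 2 nitrogen, 1 sulfur; one five-membered aromatic ring with 2 hetero atoms), on a saturated chain carbon bound to an aromatic carbon and a saturated chain carbon.

Among the measured compounds shown here, the one measured step that bears on this position, from compound 1 to compound 2, stayed within the scatter, so a swap of the group at this same place has so far not moved the half-life in this assay. On that basis no step beyond the scatter is expected here either. For compound 4 the expected value is 0.1 h, within a range from 0.04 h to 0.25 h. That expectation amounts to a step of a 1.4-fold higher number from compound 2 to compound 4 (0.15 log units; within the scatter), which is expected to remain within the scatter.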

Compound 4, half-life: > 3 h
Compound 4 was reported as a limit (the forecaster's own chance of this, stated with the estimate: 5%); middle value at least 30-fold (1.47 log units) from the limit.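

The group on this saturated chain carbon turns out to matter a great deal in this assay, which the earlier step within the scatter gave no sign of: the new group gives an at least 42-fold higher number from compound 2 to compound 4 (1.63 log units; beyond the scatter), and likewise an at least 29-fold higher number from compound 1 to compound 4 (1.46 log units; beyond the scatter). The core is the same in all three compounds, so it does not by itself set the short half-life of compound 1 and compound 2. Compound 4 gives > 3 h, which is a limit of the assay and not a number: the limit of > 3 h in this assay, at which 2 of the 4 values shown sit.

The compounds shown do not separate the contribution of the five-membered aromatic ring with 3 hetero atoms from that of the rest of the entering group. On these data alone, it also remains open whether a different group at this place, such as a carboxylic acid or an amine, would behave like the group of compound 4 in this assay.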